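The source may hold more compounds than are shown below. What is called first, only, known or untested is meant among the compounds shown, and "the series" means these compounds.

Compound 1 `Cc1cc(NC(=O)Cn2nnc(-c3ccccc3)n2)n(C2CCCCC2)n1` gives 92%
Compound 2 `COc1cccc(-c2nnn(CC(=O)Nc3cc(C)nn3C3CCCCC3)n2)c1` gives 76%

Within the data shown here, in an assay on HEK293 cells for activation of Kir3.1/Kir3.2 (Homo sapiens), read by thallium flux (on this read-out lower numbers stand for smaller maximal responses and higher numbers for larger maximal responses), compound 2 stands lowest of the two numbers so far; the nearest is compound 1 with 92%. Among the measured compounds shown here, the only measured step, a number 16 percentage points lower from compound 1 to compound 2 (beyond the scatter), concerns the same ring that changes here. Compound 3 `Cc1cc(NC(=O)Cn2nnc(-c3cccc(C#N)c3)n2)n(C2CCCCC2)n1` differs from compound 2 by cyano in place of methoxy on an aromatic carbon. For the measured compounds named here, no measured pair sets cyano against methoxy, so the direction is open; the step already seen at this position suggests a modest size at most. The expected step is a number 4 percentage points higher from compound 2 to compound 3 (within the scatter), not clearly beyond the scatter. Compound 3 is therefore estimated at 80%, in the range 62% to 96%.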

Compound 3, largest response reached (Emax), in percent of the reference or control that the assay uses: 80%
Compound 3: middle estimate and measured number agree at the digits printed, and the stated range covers the measured number.
By their numbers in this assay, from the lowest: compounds 2 and 3 (each within the scatter of the next); then compound 1.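

In this assay cyano in place of methoxy on this aromatic carbon reads a number 4 percentage points higher from compound 2 to compound 3 (within the scatter) and so does not separate the two groups. Cyano in place of hydrogen reads a number 12 percentage points lower from compound 1 to compound 3 (beyond the scatter) and thus, like methoxy in compound 2, stands beyond the scatter from compound 1 in a modest step. Nothing available explains why these two groups read alike.

Open, going by these compounds, is whether the same lower reading holds for an amine, a carboxylic acid or a longer alkoxy chain at this place. Also open, on these data alone, is how cyano or methoxy reads on the other carbons of this ring.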